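The compounds below may be only part of what the source reports. "The series", "measured", "known", "first", "only" and "open" are said of these compounds alone.

Compound 1 `COc1ccc(C(=O)/C=C/c2cccc(F)c2)c2c1C=CC(C)(C)O2` and compound 2 `COc1ccc(C(=O)/C=C/c2ccccc2)c2c1C=CC(C)(C)O2` share one core and differ only at the fluoro. In a functional assay on HT-29 cells (Homo sapiens) for antiproliferative activity, read by MTT assay, with a stated time of 24 h (on this read-out lower numbers stand for stronger inhibition and higher numbers for weaker inhibition), compound 1 gives only the limit > 10000 nM and no number. Compound 2 likewise gives only the limit > 10000 nM in this assay. The step that the two limits leave unreadable from compound 1 to compound 2 is therefore unreadable, since both values sit at the limit of > 10000 nM in this assay, at which 2 of the 2 values shown sit. Compound 3 `COc1ccc(C(=O)/C=C/c2cccc(C(F)(F)F)c2)c2c1C=CC(C)(C)O2` carries trifluoromethyl in place of hydrogen on an aromatic carbon. Among the compounds with values here, no measured step bears on this change. For compound 3 the expected step that the limit leaves unreadable from compound 2 to compound 3 is stated with little confidence and a limit is again likely. Compound 3 is estimated at 15000 nM, with a range from 4000 nM to 60000 nM.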

Compound 3, half-maximal inhibitory concentration: 9050 nM
Compound 3: the middle estimate sits 1.7-fold (0.22 log units) above what was measured, and the stated range covers the measured number.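

Of the three compounds, only compound 3, with trifluoromethyl on this aromatic carbon, gives a number in this assay, and the other two stand at an assay limit: the limit of > 10000 nM in this assay, at which 2 of the 3 values shown sit. Replacing hydrogen gives an at least 1.1-fold lower number from compound 2 to compound 3 (0.04 log units; that floor lies within the scatter), and replacing fluoro gives an at least 1.1-fold lower number from compound 1 to compound 3 (0.04 log units; that floor lies within the scatter). Going by these compounds, both are floors, so the true size of either step remains unknown.

On these data alone, it remains open whether an amine or a carboxylic acid on the same aromatic carbon would also give a readable number. Also open, as far as these compounds go, is whether trifluoromethyl elsewhere on that ring would do so.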